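A few compounds are considered here, and "the series" means these few. Any claim that something is new, unique, unknown or untested is made for them only; others in the source may bear on it.

In a functional assay on DU-145 cells (Homo sapiens) for inhibition, read by trypan blue exclusion, with a stated time of 96 h (on this read-out higher numbers stand for weaker inhibition of growth and lower numbers for stronger inhibition of growth), compound 1 `Cc1ccsc1/C=C(/SCc1ccc(Cl)cc1)C(=O)c1ccc(Cl)cc1` gives 50000 nM, level with compound 2 `Cc1ccc(S/C(=C/c2sccc2C)C(=O)c2ccc(Cl)cc2)cc1`, which gives 50000 nM; together these two stand at the highest of the three numbers, and no change at the digits printed from compound 1 to compound 2 (within the scatter). Compound 3 `Cc1ccc(CS/C(=C/c2sccc2C)C(=O)c2ccc(Cl)cc2)cc1` gives 10000 nM, so a 5.0-fold lower number from compound 1 to compound 3 (0.70 log units; beyond the scatter). Compound 4 `O=C(/C(=C\c1ccc[nH]1)SCc1ccc(Cl)cc1)c1ccc(Cl)cc1` differs from compound 1 by 1H-pyrrol-2-yl in place of 3-methylthiophen-2-yl on a double-bonded chain carbon bound to a double-bonded chain carbon. For the measured compounds named here, none of the measured steps touches that part of the molecule: no change at the digits printed from compound 1 to compound 2 (within the scatter) and a 5.0-fold lower number from compound 2 to compound 3 (0.70 log units; beyond the scatter) concern the group on a sulfur, while a 5.0-fold lower number from compound 1 to compound 3 (0.70 log units; beyond the scatter) concerns methyl in place of chloro on an aromatic carbon. Going by the values given here, with no step bearing on the change, compound 4 is expected to show no step beyond the scatter in this assay, that is no change at the digits printed from compound 1 to compound 4 (within the scatter). Compound 4 is therefore estimated at 50000 nM, range 15000 nM to 100000 nM.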

Compound 4, concentration for 50% growth inhibition: 10000 nM
Compound 4: middle estimate off by 5.0-fold (0.70 log units), on the high side; the whole stated range lies above it.
By their numbers in this assay, from the lowest: compounds 3 and 4 (each within the scatter of the next); then compounds 1 and 2 (each within the scatter of the next).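

In this assay this position is not neutral: the change to 1H-pyrrol-2-yl gives a 5.0-fold lower number from compound 1 to compound 4 (0.70 log units; beyond the scatter) with both the 4-chlorobenzyl on sulfur and the rest of the core of compound 1 kept. For the compounds shown here, the single step swaps the ring hetero atom, removes the methyl and brings in a hydrogen-bond donor together, so it cannot assign the shift to any one of these. No measurement at hand accounts for the shift.

Unsubstituted thiophen-2-yl and 1-methylpyrrol-2-yl would separate these features. Going by these compounds, whether the shift carries over to a 4-methylbenzyl on sulfur also remains open.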